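The source may report more compounds than this note shows. Statements on the series, on what has been measured and on what is new or still open speak of the compounds shown alone.

Compound 1 `Nc1sc(-c2ccc(Cl)cc2)c(-c2ccc(Cl)cc2)c1C(=O)NC1CCCCC1`: 2410 nM
Compound 2 `CC1CN(C(=O)c2c(N)sc(-c3ccc(Cl)cc3)c2-c2ccc(Cl)cc2)CCN1`: 4930 nM

Of the compounds shown here, two sharing a common core have been tested in a functional assay on A549 cells (Homo sapiens) for inhibition, read by sulforhodamine B assay, with a stated time of 72 h; a higher number here means a weaker inhibitor, a lower number a stronger inhibitor. Compound 1 gives 2410 nM, and compound 2 gives 4930 nM, so compound 2 stands as the higher of the two numbers, separated from compound 1 by a 2.0-fold higher number from compound 1 to compound 2 (0.31 log units; beyond the scatter). Compound 3 `COC(=O)c1c(N)sc(-c2ccc(Cl)cc2)c1-c1ccc(Cl)cc1` has not yet been measured in this assay. It differs from compound 2 in that (methoxy in place of 3-methylpiperazin-1-yl on a carbonyl carbon), a change that again alters the group on the carbonyl carbon, the same place that changes between compound 1 and compound 2. Among the measured compounds shown here, that single step, a 2.0-fold higher number from compound 1 to compound 2 (0.31 log units; beyond the scatter), is the only measured change bearing on the new one, and it was modest, so exchanging one carbonyl substituent for another has so far shifted the number only a little. For the measured compounds named here, no measured compound carries a methoxy on the carbonyl carbon, so the direction of the coming step is uncertain. A step of about a 1.6-fold lower number from compound 2 to compound 3 (0.22 log units; within the scatter) is expected, within the scale already seen. Compound 3 is therefore estimated at 3000 nM in this assay, with a range from 1000 nM to 10000 nM.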

Compound 3, half-maximal inhibitory concentration: 5040 nM
Compound 3: the middle estimate sits 1.7-fold (0.23 log units) below what was measured; low and high end bracket the measured number.
By their numbers in this assay, from the lowest: compound 1; then compounds 2 and 3 (each within the scatter of the next).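

In this assay, the exchange of 3-methylpiperazin-1-yl for methoxy on the carbonyl carbon is a 1.0-fold higher number from compound 2 to compound 3 (0.01 log units; within the scatter), so losing the six-membered ring and its hydrogen-bond donor, with the group going from 7 heavy atoms to 2, leaves no readable mark on the number. Set against the cyclohexylamino group, methoxy gives a 2.1-fold higher number from compound 1 to compound 3 (0.32 log units; beyond the scatter), a modest step much the same in size as a 2.0-fold higher number from compound 1 to compound 2 (0.31 log units; beyond the scatter), and this sets compound 1 apart from the other two. A nitrogen attached to the carbonyl carbon therefore does not settle the number by itself: compound 2 has one, as compound 1 does, yet its number cannot be told apart from that of compound 3, which has an oxygen there.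

Nothing measured alongside these numbers offers a reason for this pattern.

As far as these compounds go, it remains open whether a free carboxylic acid, an ethyl ester or an open-chain amine on the carbonyl carbon would stay with compound 2 and compound 3 or move beyond them. All three compounds also keep the rest of the shared core, so they say nothing about replacing either chlorine or the free amine.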